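Removing the methoxy group from compound 3

A few compounds are considered here, and "the series" means these few. Any claim that something is new, unique, unknown or untested is made for them only; others in the source may bear on it.

Among the three measured compounds, compound 3 `COc1ccc(-c2csc(N/N=C/c3ccc(Cl)cc3Cl)n2)cc1` stands lowest in a functional assay, read by spectrophotometry, with a stated time of 15 min, tested at 40 ug/mL; on this read-out higher numbers stand for a stronger effect at the one concentration tested and lower numbers for a weaker effect: compound 3 gives 79.7%, compound 1 `Clc1ccc(-c2csc(N/N=C/c3cccs3)n2)cc1` gives 83.2%, and compound 2 `Fc1ccc(-c2csc(N/N=C/c3ccc(Cl)cc3Cl)n2)cc1` gives 90%. Only the gap to compound 2 lies beyond the scatter; the gap to compound 1 lies within it. Compound 4 `Clc1ccc(/C=N/Nc2nc(-c3ccccc3)cs2)c(Cl)c1` differs from compound 3 by hydrogen in place of methoxy on an aromatic carbon. For the measured compounds named here, the one measured step that bears on this place is a number 10.3 percentage points lower from compound 2 to compound 3 (beyond the scatter), with methoxy in place of fluoro lowering the read-out. Going by the values given here, no measured step shows hydrogen in place of methoxy, so a smaller change is expected. Compound 4 is therefore expected to give 85%, between 72% and 95%. The expected step of a number 5.3 percentage points higher from compound 3 to compound 4 (within the scatter) would sit near the edge of the scatter.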

Compound 4, a percentage reported as inhibition, at one concentration (the size of the read-out at that concentration, not a potency): 78.9%
Estimate against measurement, compound 4: 6.1 percentage points above; measured number inside the range.
By their numbers in this assay, from the lowest: compounds 4, 3, 1 and 2 (each within the scatter of the next, the first and the last beyond it).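

In this assay, the change from 4-methoxyphenyl to phenyl gives a number 0.8 percentage points lower from compound 3 to compound 4 (within the scatter), so hydrogen and methoxy cannot be told apart at this place on the aromatic ring. Fluoro alone separates from the others here, with a number 11.1 percentage points lower from compound 2 to compound 4 (beyond the scatter) matching the earlier a number 10.3 percentage points lower from compound 2 to compound 3 (beyond the scatter), so the drop seen with methoxy is not specific to that group. Still open, from the compounds shown here alone, is what a bromo group, an amine or a carboxylic acid would give on this aromatic carbon, and whether fluoro keeps its edge with a different group on the other side of the shared core. Nothing measured here gives a reason for this pattern.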